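Removing the cinnamamide from a trimethoxybenzoyl aniline

The source may hold more compounds than are shown below. What is called first, only, known or untested is meant among the compounds shown, and "the series" means these compounds.

Measured compounds:
compound 1, `COc1ccc(/C=C/C(=O)Nc2cc(C(=O)c3cc(OC)c(OC)c(OC)c3)cc(OC)c2OC)cc1`, 4800 nM
compound 2, `COc1cccc(/C=C/C(=O)Nc2cc(C(=O)c3cc(OC)c(OC)c(OC)c3)cc(OC)c2OC)c1`, 10700 nM

Both compounds share a trimethoxybenzoyl-substituted aniline core and differ only in the position of the methoxy group on the cinnamoyl ring. Within the data shown here, in a functional assay on COLO 205 cells (Homo sapiens) for cytotoxicity, read by MTT assay, with a stated time of 72 h (a higher number here means a weaker inhibitor, a lower number a stronger inhibitor), compound 2 gives 10700 nM, the higher of the two numbers; the single known step, a 2.2-fold higher number from compound 1 to compound 2 (0.35 log units; beyond the scatter), is modest but beyond the scatter.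

Compound 3, `COc1cc(C(=O)c2cc(OC)c(OC)c(OC)c2)cc(N)c1OC`, is not yet measured. Relative to compound 2 it carries hydrogen in place of (2-(3-methoxyphenyl)ethenyl)carbonyl on a nitrogen on an aromatic ring, so the whole cinnamamide side chain is gone and the free amine remains.

Among the measured compounds shown here, no measured step bears directly on this change. For the measured compounds named here, the only step available, from compound 1 to compound 2, concerns a methoxy position on the part that is removed, and it was modest. It therefore gives no guide to the size or direction of the step in this assay for compound 3, and the expectation must stay wide. The estimated step is a 3.6-fold lower number from compound 2 to compound 3 (0.55 log units; beyond the scatter), with the direction uncertain. Compound 3 is expected to give about 3000 nM, within a range from 300 nM to 30000 nM.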

Compound 3, half-maximal inhibitory concentration: 4400 nM
For compound 3 the middle estimate is 1.5-fold (0.17 log units) below the measured one, and the stated range covers the measured number.
By their numbers in this assay, from the lowest: compounds 3 and 1 (each within the scatter of the next); then compound 2.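

Measured in this assay the loss of the (2-(3-methoxyphenyl)ethenyl)carbonyl group, with hydrogen entering on the nitrogen, gives a 2.4-fold lower number from compound 2 to compound 3 (0.39 log units; beyond the scatter) and the matching loss of the (2-(4-methoxyphenyl)ethenyl)carbonyl group gives a 1.1-fold lower number from compound 1 to compound 3 (0.04 log units; within the scatter) on the same nitrogen. The earlier step concerned only where the methoxy group sits on the side chain, whereas these steps show that the free amine of compound 3 keeps a number level with compound 1 and lower than that of compound 2, so neither side chain shown brings a lower number than hydrogen on this nitrogen. Nothing available here accounts for this result.

The compounds shown leave open whether a small acetyl group on this nitrogen, or a saturated propanoyl link to the methoxyphenyl ring in place of the ethenyl one, would move the number in either direction. They also leave open whether the amine itself matters, since a hydroxyl group or a plain hydrogen at that place on the aromatic ring would test it directly.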